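The source may report more compounds than this note shows. Statements on the series, on what has been measured and on what is new or still open speak of the compounds shown alone.

The measured compounds: compound 1 `CCCCCCCCCCCCCCCCc1c(C)c(N(C)C)nc(C)c1O`, 84%; compound 2 `Cc1c(N(C)C)nc(CCCCCCCCCCO)c(O)c1C`, 87%; compound 3 `CCCCCCCCCCCCCCCCc1c(C)c(N2CCC2)nc(C)c1O`, 92%.

In a functional assay on cells (Lymphocyte, Homo sapiens), read by trypan blue exclusion, with a stated time of 16 h, tested at 2.5 uM (on this read-out lower numbers stand for a weaker effect and higher numbers for a stronger effect at the one concentration tested), compound 2 gives 87%, the second highest of the three numbers; compound 1 lies nearest with 84% and compound 3 furthest with 92%, both gaps within the scatter. Compound 4 `CCCCCCCCCCCCCCCCCCCc1nc(N(C)C)c(C)c(C)c1O` differs from compound 2 by nonyl in place of hydroxy on a saturated chain carbon, ten or more bonds along the chain from an aromatic carbon. Among the compounds with values here, the one measured step, a number 8 percentage points higher from compound 1 to compound 3 (within the scatter), concerns the amine and does not bear on this change, and no measured pair tests an exchange at a saturated chain carbon. Compounds 1 and 3, which carry a long chain without a hydroxy, give numbers close to that of compound 2, so no step beyond the scatter is expected in this assay. Compound 4 is therefore expected to give 86% (range 72% to 96%). The expected step is a number 1 percentage points lower from compound 2 to compound 4 (within the scatter).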

Compound 4, a percentage reported as activity, at one concentration (the size of the read-out at that concentration, not a potency): 76%
Compound 4: middle estimate off by 10 percentage points, on the high side, within the range that was stated.
By their numbers in this assay, from the lowest: compounds 4, 1, 2 and 3 (each within the scatter of the next, the first and the last beyond it).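

In this assay, within the data shown here, nonyl in place of hydroxy on a saturated chain carbon, ten or more bonds along the chain from an aromatic carbon, gives a number 11 percentage points lower from compound 2 to compound 4 (beyond the scatter), the first step here beyond the scatter. Among these compounds, the only earlier step, a number 8 percentage points higher from compound 1 to compound 3 (within the scatter), concerned the amine and so did not test this position. No measurement shown here accounts for the new step. The compounds shown leave open whether a carboxylic acid or an amine in place of the hydroxy would hold the number of compound 2, and how a shorter chain ending in hydroxy would read.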